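This account rests on a few compounds, and the source may have more. Where it says the series, first, only, none or still open, it means among the compounds named here.

Measured so far in a functional assay on DLD-1 cells (Homo sapiens) for antiproliferative activity, read by CellTiter-Glo, with a stated time of 72 h; on this read-out lower numbers stand for stronger inhibition and higher numbers for weaker inhibition:
- compound 1 `Cc1cc(C)c(S(=O)(=O)N2CCC(C(=O)N3CCC(C)CC3)CC2)c(C)c1` gives > 5000 nM
- compound 2 `CCCOc1ccc(S(=O)(=O)N2CCC(N3CCC(C)CC3)CC2)cc1` gives 452 nM

For the measured compounds named here, compound 1 stands at the assay limit: its reading of > 5000 nM is a limit, not a number, and it is the one such reading among the two values shown (the limit of > 5000 nM in this assay, at which 1 of the 2 values shown sits). Compound 2, by contrast, gives a measured value of 452 nM in this assay.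

Compound 3 `Cc1cc(C)c(S(=O)(=O)N2CCC(N3CC(C)CC(C)C3)CC2)c(C)c1` is not yet measured. It differs from compound 1 in one place: 3,5-dimethylpiperidin-1-yl in place of (4-methylpiperidin-1-yl)carbonyl on a saturated ring carbon.

Going by the values given here, no step between two measured compounds is available to size this change. Still, compound 2, with its reading of 452 nM, shows that compounds of this general kind can give a measurable value rather than a limit. Compound 3 is therefore expected to move below the limit, with an estimated step of an at least 5.5-fold lower number from compound 1 to compound 3 (0.74 log units; beyond the scatter). For compound 3 the estimate is 900 nM, in the range of 150 nM to 5000 nM, with a real chance that only a limit is again reported.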

Compound 3, half-maximal inhibitory concentration: 17 nM
For compound 3 the middle estimate is 53-fold (1.72 log units) above the measured one; the measured number lies below the stated range.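

In this assay, replacing (4-methylpiperidin-1-yl)carbonyl with 3,5-dimethylpiperidin-1-yl on this saturated ring carbon gives an at least 290-fold lower number from compound 1 to compound 3 (2.46 log units; beyond the scatter). For the compounds shown here, the earlier compounds offered no pair differing in one place, so this is the first evidence that this position alone can carry a large change in the read-out on the shared core. Compound 1 stands only as a limit, so the step is a bound and not a full size: the limit of > 5000 nM in this assay, at which 1 of the 3 values shown sits.

This single pair cannot separate the loss of the carbonyl from the arrival of the two methyl groups, and a 4-methylpiperidin-1-yl at the same place on the core of compound 1 would be needed to tell them apart. From the compounds shown here alone, how an unsubstituted piperidin-1-yl or a morpholin-4-yl would read at this position also remains open.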